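A few compounds are considered here, and "the series" means these few. Any claim that something is new, unique, unknown or untested is made for them only; others in the source may bear on it.

Within the data shown here, measured compounds so far. Compound 1 `COc1ccc(/C=C2\CCC/C(=C\c3cccc(OC)c3OC)C2=O)cc1` gives 18600 nM. Compound 2 `COc1ccc(/C=C2\CCC/C(=C\c3cccc(OC)c3OC)C2=O)c(OC)c1` gives only a limit of the assay, > 20000 nM. Compound 3 `COc1ccc(/C=C2\CCC/C(=C\c3ccc(OC)c(OC)c3)C2=O)cc1` gives 7800 nM.

All three values come from a functional assay on MCF7 cells (Homo sapiens) for cytotoxicity, read by MTT assay, with a stated time of 72 h; a higher number here means a weaker inhibitor, a lower number a stronger inhibitor. Compound 3 has the lowest number of the two that are numbers, and its gap to compound 1 is beyond the usual scatter; the two share the same atoms joined differently, and the difference between their cores is not broken down here. From compound 1 to compound 2 the change is methoxy in place of hydrogen on an aromatic carbon, and the step is an at least 1.0-fold higher number from compound 1 to compound 2 (0.03 log units; that floor lies within the scatter); the size of that step cannot be pinned down more closely because of the limit of > 20000 nM in this assay, at which 1 of the 3 values shown sits.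

Compound 4 `COc1ccc(/C=C2\CCC/C(=C\c3ccc(OC)c(OC)c3)C2=O)cc1OC` is not yet measured in this assay. It differs from compound 3 by methoxy in place of hydrogen on an aromatic carbon, the same kind of change as from compound 1 to compound 2, though the surroundings differ: here the entering methoxy is ortho to a methoxy group and meta to a large group, whereas before it was ortho to a large group and meta to a methoxy group. Resting on compound 1 to compound 2, a modest rise in the number is expected, a 1.5-fold higher number from compound 3 to compound 4 (0.19 log units; within the scatter). For compound 4 the estimate is 12000 nM, between 5000 nM and 30000 nM.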

Compound 4, half-maximal inhibitory concentration: 13500 nM
Beside the measured number, compound 4's estimate is 1.1-fold (0.05 log units) below it; low and high end bracket the measured number.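

In this assay, methoxy in place of hydrogen on an aromatic carbon gives a 1.7-fold higher number from compound 3 to compound 4 (0.24 log units; within the scatter), so on this core the change does not separate the two compounds beyond the scatter. This gives no sign of a large penalty for the change on the core of compound 3, but it does not show that the change carries over with the same size from one core to the other, and the entering methoxy also has different surroundings in the two cases: the same change on two cores in this assay, an at least 1.0-fold higher number (0.03 log units; that floor lies within the scatter) from compound 1 to compound 2 and a 1.7-fold higher number (0.24 log units; within the scatter) from compound 3 to compound 4; the limit leaves it open whether they differ The earlier step stays a floor and not a size because one end of it is a limit, so the two steps cannot be set against each other more closely: the limit of > 20000 nM in this assay, at which 1 of the 4 values shown sits.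

The compounds shown leave open how a hydroxyl, an amine or a carboxylic acid would read in place of the entering methoxy in this assay. They also leave open whether a longer chain than methoxy on the same aromatic carbon would move the number beyond the scatter.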